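The source may hold more compounds than are shown below. What is called first, only, known or untested is meant among the compounds shown, and "the series" means these compounds.

Measured so far:
- compound 1, `Nc1cc(N)c2nc(-c3ccccc3)c(NCc3ccc(Cl)c(Cl)c3)nc2c1`: 9770 nM
- compound 2, `Nc1cc(N)c2nc(-c3ccccc3)c(Sc3ccc(F)cc3)nc2c1`: 50100 nM
- compound 3, `COc1cc(CNc2nc3cc(N)cc(N)c3nc2-c2ccccc2)cc(OC)c1OC`: 4470 nM

In a functional assay on SW-620 cells (Homo sapiens) for inhibition, read by sulforhodamine B assay, with a stated time of 48 h (on this read-out higher numbers stand for weaker inhibition of growth and lower numbers for stronger inhibition of growth), compound 2 gives 50100 nM, the highest of the three numbers. The nearest to it is compound 1 with 9770 nM, and the furthest is compound 3 with 4470 nM; both gaps lie beyond the scatter, so compound 2 is the weakest of the three in this assay. For the measured compounds named here, the three compounds share the same core and differ in the group on the carbon next to the phenyl-bearing carbon of that core, but no pair differs in one place only, so no single step between measured compounds can be read off.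

Compound 4, `Nc1cc(N)c2nc(-c3ccccc3)c(Sc3ccc(Cl)c(Cl)c3)nc2c1`, is the next compound for this assay. It differs from compound 2 by 3,4-dichlorophenyl in place of 4-fluorophenyl on a sulfur. The 3,4-dichlorophenyl group also appears in compound 1, which gives a lower number than compound 2 in this assay, though there it sits on a different linker, so nothing here fixes the size of the step. The expectation is a moderate move to a lower number, plausibly beyond the scatter, as the estimated step of a 2.5-fold lower number from compound 2 to compound 4 (0.40 log units; beyond the scatter). Compound 4 is expected at 20000 nM, with a range from 6000 nM to 60000 nM.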

Compound 4, concentration for total growth inhibition: 83200 nM
Estimate against measurement, compound 4: 4.2-fold (0.62 log units) below, outside the stated range (above it).
By their numbers in this assay, from the lowest: compound 3; then compound 1; then compounds 2 and 4 (each within the scatter of the next).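

In this assay, for the compounds shown here, the first single-place step gives a 1.7-fold higher number from compound 2 to compound 4 (0.22 log units; within the scatter), so on the sulfur this exchange of 4-fluorophenyl for 3,4-dichlorophenyl does not separate the two compounds. The 3,4-dichlorophenyl group therefore does not bring a lower number in this setting: with that same group, compound 1, which carries it on a different linker, gives 9770 nM, while compound 4 gives 83200 nM. No measured property accompanies these compounds, and the result stays unexplained.

Going by these compounds alone, with only two aryl groups on the sulfur, it remains open whether any group in this place moves the number beyond the scatter, for example a plain phenyl, a pyridine ring or a benzyl group. Also open, going by these compounds, is whether the difference between compound 1 and compound 4 follows the linker with other aryl groups, which would need a matching pair carrying, for example, 4-fluorophenyl on the linker of compound 1.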